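Lengthening the Amide Chain: Compound 3 to Compound 4

A few compounds are considered here, and "the series" means these few. Any claim that something is new, unique, unknown or untested is made for them only; others in the source may bear on it.

Measured compounds:
- compound 1, `CCC/C=C/C(=O)Nc1cccc(Oc2nc(Nc3cccc(OC)c3)nc3ccsc23)c1`: 5560 nM
- compound 2, `C/C=C/C(=O)Nc1cccc(Oc2nc(Nc3cccc(C#N)c3)nc3ccsc23)c1`: 11300 nM
- compound 3, `CC/C=C/C(=O)Nc1cccc(Oc2nc(Nc3cccc(C#N)c3)nc3ccsc23)c1`: 14900 nM

In a functional assay on A549 cells (Homo sapiens) for inhibition, read by MTT assay, with a stated time of 72 h (a lower number here means a stronger inhibitor, a higher number a weaker inhibitor), compound 3 stands highest of the three numbers. Its nearest neighbour is compound 2, and the step of a 1.3-fold higher number from compound 2 to compound 3 (0.12 log units; within the scatter) lies within the scatter. Compound 1 is furthest away, with a lower number, but it differs from compound 3 in two places, so its value alone shows only that much. The next compound, compound 4, `CCC/C=C/C(=O)Nc1cccc(Oc2nc(Nc3cccc(C#N)c3)nc3ccsc23)c1`, differs from compound 3 in a single spot: methyl in place of hydrogen on a saturated chain carbon, two bonds along the chain from a double-bonded chain carbon. Within the data shown here, the one measured step of this kind, lengthening the same chain by a methyl from compound 2 to compound 3, did not move the number beyond the scatter. The longer chain of compound 4 is also carried, with a different other substituent, by compound 1, which gives 5560 nM. On that basis no step beyond the scatter is expected in this assay , and the expected step of a 1.0-fold higher number from compound 3 to compound 4 (0.00 log units; within the scatter) is meant as essentially flat. Compound 4 is therefore estimated at 15000 nM, with a range from 7000 nM to 32000 nM.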

Compound 4, half-maximal inhibitory concentration: 16700 nM
Estimate against measurement, compound 4: 1.1-fold (0.05 log units) below; low and high end bracket the measured number.
By their numbers in this assay, from the lowest: compound 1; then compounds 2, 3 and 4 (each within the scatter of the next).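

In this assay, the chain tolerates extra carbon on the cyano series: a 1.1-fold higher number from compound 3 to compound 4 (0.05 log units; within the scatter) and a 1.5-fold higher number from compound 2 to compound 4 (0.17 log units; within the scatter), so neither added methyl nor added ethyl at this part of the chain gives a step beyond the scatter. Compound 4 also offers the first comparison at the aromatic carbon with the chain held the same, and cyano in place of methoxy gives a 3.0-fold higher number from compound 1 to compound 4 (0.48 log units; beyond the scatter), so among these compounds only this change, not the chain length, moves the number beyond the scatter. No measurement shown here bears on why this is so.

On these data alone, whether a longer chain, or an amine at the end of the chain, would keep the number as flat stays open. So does whether a chlorine or a carboxylic acid at that aromatic carbon would give a lower or a higher number than methoxy and cyano.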